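A few compounds are considered here, and "the series" means these few. Any claim that something is new, unique, unknown or untested is made for them only; others in the source may bear on it.

Measured so far:
- compound 1 `CC1(Cc2ccccc2)CC(S(=O)(=O)c2ccc(F)cc2)=C(c2ccc(/C(N)=N/O)cc2)O1`: 102000 nM
- compound 2 `CC1(Cc2cc(C(F)(F)F)cc(C(F)(F)F)c2)CC(S(=O)(=O)c2ccc(F)cc2)=C(c2ccc(/C(N)=N/O)cc2)O1`: 43100 nM
- compound 3 `COc1ccc(CC2(C)CC(S(=O)(=O)c3ccc(F)cc3)=C(c3ccc(/C(N)=N/O)cc3)O2)cc1`: > 100000 nM

In an ADME assay on cells (Peritoneal macrophage, Mus musculus, strain Balb/c) for cytotoxicity, read by resazurin assay, with a stated time of 72 h (on this read-out higher numbers stand for lower toxicity in this test and lower numbers for higher toxicity in this test), compound 3 gives only a limit, > 100000 nM. Compound 1 sits at 102000 nM in this assay, so compound 3 stands at or beyond the upper edge of the values shown, with nothing read beyond it. Among the measured compounds shown here, the single step between compounds differing in one place, a step that the limit leaves unreadable from compound 1 to compound 3, cannot be sized because of the limit of > 100000 nM in this assay, at which 1 of the 3 values shown sits. For the measured compounds named here, compound 2 shows 43100 nM, the lowest number in the set, and differs from compound 1 in two places, so no single step is drawn from it.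

Compound 4 `CC1(Cc2ccc(-c3ccccc3)cc2)CC(S(=O)(=O)c2ccc(F)cc2)=C(c2ccc(/C(N)=N/O)cc2)O1` differs from compound 3 by phenyl in place of methoxy on an aromatic carbon. Going by the values given here, no measured step bears directly on this change; the three values all sit at the upper end of the range, and the one readable comparison is the pair of compounds 1 and 2. Compound 4 is therefore expected near the same region, with the step of an at least 1.5-fold lower number from compound 3 to compound 4 (0.18 log units; that floor lies within the scatter), and a fair chance that only a limit is returned again. The estimate for compound 4 in this assay is 65000 nM, between 25000 nM and 160000 nM.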

Compound 4, half-maximal cytotoxic concentration: 33900 nM
Compound 4: the middle estimate sits 1.9-fold (0.28 log units) above what was measured; low and high end bracket the measured number.
By their numbers in this assay, from the lowest: compounds 4 and 2 (each within the scatter of the next); then compound 1.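

In this assay, the aromatic carbon para to a large group now gives its first readable step, with phenyl in place of hydrogen: a 3.0-fold lower number from compound 1 to compound 4 (0.48 log units; beyond the scatter). Phenyl in place of methoxy at the same carbon gives an at least 2.9-fold lower number from compound 3 to compound 4 (0.46 log units; beyond the scatter), and that size is only a floor, since the value of compound 3 is a limit: the limit of > 100000 nM in this assay, at which 1 of the 4 values shown sits.
Across compounds 1, 3 and 4, phenyl at this carbon is the one change that gives a readable lower number, which here means higher toxicity in this test.

Still open, going by these compounds, is whether that lower number is specific to phenyl, or would also come with an amine, a carboxylic acid or a longer alkyl chain at this carbon. Where methoxy stands relative to hydrogen also remains open, as the step from compound 1 to compound 3 cannot be read.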